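Bromo for Cyano on a Shared Amide Core

This account rests on a few compounds, and the source may have more. Where it says the series, first, only, none or still open, it means among the compounds named here.

The series rests on one shared core carrying an amide to a tetrahydropyranylmethyl chain and an arylamino group. Compound 1 `O=C(NCC1CCOCC1)c1cnc(Nc2cccc(F)c2)cc1C1CC1`, compound 2 `N#Cc1cccc(Nc2cc(C3CC3)c(C(=O)NCC3CCOCC3)cn2)c1` and compound 3 `CC(C)(C)c1cc(Nc2ccc(Cl)cc2Cl)ncc1C(=O)NCC1CCOCC1` were all followed in an in vitro ADME assay on microsomes from liver (Homo sapiens) for metabolic stability; a lower number here means slower removal, a higher number faster removal of the compound. For compound 1 this assay gives "not determined" (no result reported). Compound 2 likewise stands without a number, with "not determined" (no result reported) in this assay. Among the measured compounds shown here, compound 3 is the only member with a reported result, and that result is a limit of the assay rather than a number: in this assay compound 3 gives < 0.5 mL.min-1.g-1. The picture is therefore thin, as the only anchor is the limit of < 0.5 mL.min-1.g-1 in this assay, at which 1 of the 3 values shown sits.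

Compound 4 `O=C(NCC1CCOCC1)c1cnc(Nc2cccc(Br)c2)cc1C1CC1` has not yet been measured. It differs from compound 2 by bromo in place of cyano on an aromatic carbon. For the measured compounds named here, no measured step of this kind exists in the set, so nothing shows how this assay responds to it. The expectation is a step of no clear direction and of a size that stays within the usual scatter. For compound 4 the estimated value in this assay is 1 mL.min-1.g-1, with an expected range from 0.4 mL.min-1.g-1 to 3 mL.min-1.g-1.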

Compound 4, intrinsic clearance in microsomes: < 0.5 mL.min-1.g-1
Compound 4 ended at the assay's limit (the forecaster's own chance of this, stated with the estimate: 30%); middle value at least 2.0-fold (0.30 log units) from the limit.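

In this assay compound 4 gives < 0.5 mL.min-1.g-1, which is a limit of the assay and not a number. Among the compounds shown here, compound 2 gives "not determined" (no result reported), so no step between compound 2 and compound 4 can be read. The compounds shown leave open whether bromo in place of cyano changes the rate of removal, and how compounds differ at the limit: the limit of < 0.5 mL.min-1.g-1 in this assay, at which 2 of the 4 values shown sit.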